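The source may report more compounds than this note shows. Statements on the series, on what has been measured and on what is new or still open speak of the compounds shown alone.

Working notes on the series: in a functional assay on K562 cells (Homo sapiens) for antiproliferative activity, read by MTT assay (on this read-out lower numbers stand for stronger inhibition and higher numbers for weaker inhibition), compound 3 (`C/C(=N\NC(=S)NCCCCCC(=O)NO)c1ccc(Br)cc1`) gives 960 nM as the lowest of the three numbers so far. Compound 1 (`Cc1ccccc1/C(=N/NC(=S)NCCCCCC(=O)NO)c1ccccc1`) gives 3510 nM and compound 2 (`O=C(CCCCCNC(=S)N/N=C(\c1ccccc1)c1ccccc1F)NO`) gives 4630 nM in the same read-out.

Compound 4 (`C/C(=N\NC(=S)NCCCCCC(=O)NO)c1cccc(Br)c1`) is not yet measured. The change from compound 3 is 3-bromophenyl in place of 4-bromophenyl on a carbon with a double bond to nitrogen and leaves the atoms the same but joined differently.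

Among the compounds with values here, the only measured step (a 1.3-fold higher number from compound 1 to compound 2 (0.12 log units; within the scatter)) is fluoro in place of methyl on an aromatic carbon. That is a different kind of change and stayed within the scatter, so it is only a weak guide. Within the data shown here, no measured pair moves a bromine. No step beyond the scatter is expected in this assay, with a slight lean towards a higher number, as compound 3 sits at the low end with 960 nM on record. The expected change is a 1.4-fold higher number from compound 3 to compound 4 (0.13 log units; within the scatter) for now. Compound 4 is expected at 1300 nM with an estimated range from 600 nM to 3000 nM in this read-out.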

Compound 4, half-maximal inhibitory concentration: 1260 nM
For compound 4 the middle estimate is 1.0-fold (0.01 log units) above the measured one; low and high end bracket the measured number.
By their numbers in this assay, from the lowest: compounds 3 and 4 (each within the scatter of the next); then compounds 1 and 2 (each within the scatter of the next).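

In this assay, within the data shown here, 3-bromophenyl in place of 4-bromophenyl on a carbon with a double bond to nitrogen gives a 1.3-fold higher number from compound 3 to compound 4 (0.12 log units; within the scatter), the first measured step that moves a bromine rather than exchanging one group for another. With the same atoms joined differently, this read-out does not separate the two bromophenyl isomers at this place. Nothing on hand accounts for this outcome.

From the compounds shown here alone, whether an aminophenyl or a methoxyphenyl group at this place, or a longer chain ending in the same hydroxamic acid, would stay in the same range remains open. Compounds 1 and 2 differ from compounds 3 and 4 in more than one place, so the series does not yet assign any difference between these two pairs to a single group.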